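A few compounds are considered here, and "the series" means these few. Any claim that something is new, unique, unknown or untested is made for them only; others in the source may bear on it.

Measured so far:
- compound 1 `CCCCC[Se]c1nc(NCc2ccc(SC)cc2)c2ccccc2n1`: 34700 nM
- compound 2 `CSc1ccc(CNc2nc([SeH])nc3ccccc23)cc1`: 48100 nM
- compound 3 `Nc1nc([SeH])nc2ncccc12`: 37300 nM

All three numbers come from a functional assay on MCF7 cells (Homo sapiens) for cytotoxicity, read by MTT assay, with a stated time of 72 h (on this read-out lower numbers stand for stronger inhibition of growth and higher numbers for weaker inhibition of growth), and sit close together. Compound 2 and compound 1 differ in one place, (pentyl in place of hydrogen on a selenium), and the step is a 1.4-fold lower number from compound 2 to compound 1 (0.14 log units; within the scatter). Compound 3 shares the selenium-bearing hydrogen of compound 2 but carries a different core; the difference between the two cores is not broken down here, and the two values show nothing beyond what is given for each of them.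

Compound 4 `CCCCC[Se]c1nc(N)c2cccnc2n1` is not yet measured. It differs from compound 3 by pentyl in place of hydrogen on a selenium, the same change as that from compound 2 to compound 1, at a selenium with the same surroundings. Across the three measured compounds, changes of core and of the selenium substituent have left the numbers close together, so no large move is anticipated. The step from compound 3 to compound 4 is expected to be a 1.3-fold lower number from compound 3 to compound 4 (0.12 log units; within the scatter), beside the earlier step of a 1.4-fold lower number from compound 2 to compound 1 (0.14 log units; within the scatter); that expectation rests on the measured pair alone. For compound 4 in this assay the estimate is 28000 nM, with a range from 12000 nM to 65000 nM.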

Compound 4, concentration for 50% growth inhibition: 22700 nM
For compound 4 the middle estimate is 1.2-fold (0.09 log units) above the measured one; the range from low to high includes it.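

In this assay, pentyl in place of hydrogen on the selenium gives a 1.6-fold lower number from compound 3 to compound 4 (0.22 log units; within the scatter) on the core of compound 3, and this step can be set directly against the one already seen on the core of compound 1. The two steps do not differ: the same change on two cores in this assay, a 1.4-fold lower number (0.14 log units; within the scatter) from compound 2 to compound 1 and a 1.6-fold lower number (0.22 log units; within the scatter) from compound 3 to compound 4, 1.2-fold (0.07 log units) apart, within the scatter of two such steps
Neither step lies beyond the scatter, so the change carries across these two cores as one that leaves the number effectively in place, not as a demonstrated gain in growth inhibition on either core, and two pairs say nothing about a third core.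

The compounds shown leave open whether a shorter chain such as methyl, a longer chain such as octyl, or a benzyl group on the selenium would give a step beyond the scatter. They also leave open what an amine or a carboxylic acid at the end of the pentyl chain would do on either core.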